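Cyclopentyloxy in place of propoxy on the shared core

The source may hold more compounds than are shown below. What is called first, only, known or untested is meant among the compounds shown, and "the series" means these compounds.

Compound 1 `CCC1CCN(c2cc(C(F)(F)F)ccc2CNC(=O)C(C)c2ccc(NS(C)(=O)=O)c(F)c2)CC1` and compound 2 `CCCOc1cc(C(F)(F)F)ccc1CNC(=O)C(C)c1ccc(NS(C)(=O)=O)c(F)c1` share a core and differ at one aromatic carbon. In an assay on CHO cells for antagonist activity at transient receptor potential cation channel subfamily V member 1 (Homo sapiens), read by FLIPR (on this read-out higher numbers stand for weaker inhibition and lower numbers for stronger inhibition), compound 1 gives 0.7 nM, and compound 2 gives 2 nM; the change of propoxy in place of 4-ethylpiperidin-1-yl on an aromatic carbon brought a 2.9-fold higher number from compound 1 to compound 2 (0.46 log units; beyond the scatter). Going by the values given here, compound 2 thus stands at the higher of the two numbers, with compound 1 as its only neighbour.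

Compound 3 `CC(C(=O)NCc1ccc(C(F)(F)F)cc1OC1CCCC1)c1ccc(NS(C)(=O)=O)c(F)c1` keeps the ether oxygen of compound 2 and changes only what hangs on it: cyclopentyl in place of propyl on an oxygen on an aromatic ring. Among the compounds with values here, no measured step concerns this exact change, and the one known step at this carbon compares an amine ring with a chain, not two ethers, so it bears only loosely. With a ring replacing a chain at this oxygen, compound 3 is expected to stay close to compound 2, with a step of a 1.3-fold lower number from compound 2 to compound 3 (0.12 log units; within the scatter) that does not exceed the scatter. Compound 3 is therefore estimated at 1.5 nM, with a likely range from 0.5 nM to 5 nM.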

Compound 3, inhibition constant: 0.6 nM
For compound 3 the middle estimate is 2.5-fold (0.40 log units) above the measured one, and the stated range covers the measured number.
By their numbers in this assay, from the lowest: compounds 3 and 1 (each within the scatter of the next); then compound 2.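

At this aromatic carbon, what hangs on the ether oxygen matters: cyclopentyl in place of propyl gives in this assay a 3.3-fold lower number from compound 2 to compound 3 (0.52 log units; beyond the scatter) and this step lies beyond the scatter. An ether can also sit level with the amine ring, since cyclopentyloxy in place of 4-ethylpiperidin-1-yl gives a 1.2-fold lower number from compound 1 to compound 3 (0.07 log units; within the scatter) and this step lies within the scatter, so the gap seen with propoxy does not hold for every ether here. Nothing measured here says why the cyclopentyl group differs from the propyl group on this oxygen.

Cyclopentyl brings both a ring and more carbon than propyl, so these compounds cannot tell which of the two goes with the lower number. A pentyl chain on the same oxygen would separate them, and cyclobutyl or cyclohexyl would show whether ring size counts.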